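Swapping Amino for Methylsulfanyl on the Chalcone Ring

The source may hold more compounds than are shown below. What is called first, only, known or untested is meant among the compounds shown, and "the series" means these compounds.

Compound 1 `COc1ccc2c(/C=C/C(=O)c3cc(N)c(OC)c(OC)c3)cn(C)c2c1`: 156 nM
Compound 2 `COc1cc(C(=O)/C=C/c2cn(C)c3ccccc23)cc(N)c1OC`: 441 nM

In a functional assay on A2780 cells (Homo sapiens) for antiproliferative activity, read by MTT assay, with a stated time of 48 h (on this read-out lower numbers stand for stronger inhibition and higher numbers for weaker inhibition), compound 2 gives the highest of the two numbers measured, its nearest neighbour being compound 1 at 156 nM, reached by the step of a 2.8-fold higher number from compound 1 to compound 2 (0.45 log units; beyond the scatter). Compound 3 `COc1cc(C(=O)/C=C/c2cn(C)c3ccccc23)cc(SC)c1OC` differs from compound 2 by methylsulfanyl in place of amino on an aromatic carbon. Among the compounds with values here, no measured step involves this change; the only step known concerns a methoxy group elsewhere, so the expectation for compound 3 rests on the structural change alone and is uncertain. A modest rise in the number is expected, the step of a 1.8-fold higher number from compound 2 to compound 3 (0.26 log units; within the scatter). Compound 3 is therefore estimated at 800 nM, within 250 nM to 2500 nM.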

Compound 3, half-maximal inhibitory concentration: 193 nM
The estimate for compound 3 lay 4.1-fold (0.62 log units) above the measured number; the whole stated range lies above it.
By their numbers in this assay, from the lowest: compounds 1 and 3 (each within the scatter of the next); then compound 2.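

At this position, ortho to a methoxy group, methylsulfanyl in place of amino gives [ a 2.3-fold lower number from compound 2 to compound 3 (0.36 log units; beyond the scatter) ] in this assay. The amino group, with its hydrogen-bond donor, is therefore not needed here for the number to fall, as methylsulfanyl has no such donor and still gives the lower number. No measurement shown explains this step.

From the compounds shown here alone, it remains open how a hydroxy or methylsulfonyl group would fare at this position. Also open, going by these compounds, is whether the same swap gives a similar step on the core of compound 1, which carries the additional methoxy group.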